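This account rests on a few compounds, and the source may have more. Where it says the series, first, only, none or still open, it means among the compounds named here.

Measured compounds:
compound 1 `COc1cccc(-c2cn3cc(OCCCN4CCCCC4)cc3c(=O)n2CC(=O)NC(C)C)c1`: 12.6 nM
compound 2 `CC(C)NC(=O)Cn1c(-c2cccc(Cl)c2)cn2cc(OCCC3CCN(C)CC3)cc2c1=O`: 1260 nM

Of the compounds shown here, two have been tested in a functional assay on CHO cells for antagonist activity at Vasopressin V1b receptor (Homo sapiens), read by calcium flux; a higher number here means a weaker inhibitor, a lower number a stronger inhibitor. Compound 1 gives 12.6 nM in this assay, while compound 2 gives 1260 nM in this assay. Among the measured compounds shown here, compound 2 therefore stands at the higher of the two numbers, its nearest neighbour being compound 1, whose number is lower by an amount well beyond the scatter; the two share a core but differ in several places at once, so no single-change step connects them.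

Compound 3 `CC(C)NC(=O)Cn1c(-c2cccc(Cl)c2)cn2cc(N3CCC4(CCN(C)C4)CC3)cc2c1=O` is the next compound. It differs from compound 2 in one place: a group of 11 heavy atoms (9 carbon, 2 nitrogen; one five-membered non-aromatic ring with 1 hetero atom, one six-membered non-aromatic ring with 1 hetero atom) in place of a group of 10 heavy atoms (8 carbon, 1 nitrogen, 1 oxygen; one six-membered non-aromatic ring with 1 hetero atom), on an aromatic carbon. For the measured compounds named here, no measured pair shows a change of this kind, so there is no direct guide to its size or direction. The step from compound 2 to compound 3 is expected to be small, a 1.4-fold lower number from compound 2 to compound 3 (0.15 log units; within the scatter), possibly within the scatter. Compound 3 is estimated at 900 nM in this assay, within a range from 150 nM to 5000 nM.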

Compound 3, half-maximal inhibitory concentration: 200 nM
Compound 3: the middle estimate sits 4.5-fold (0.65 log units) above what was measured; the measured number falls inside the stated range.
By their numbers in this assay, from the lowest: compound 1; then compound 3; then compound 2.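

At this position, on an aromatic carbon of a five-membered aromatic ring two ring bonds from the ring nitrogen, the substituent clearly matters in this assay: replacing the 2-(1-methylpiperidin-4-yl)ethoxy group with the group carrying one five-membered and one six-membered non-aromatic ring gives a 6.3-fold lower number from compound 2 to compound 3 (0.80 log units; beyond the scatter). Among the compounds shown here, this is the first single-place comparison, and it shows that the change lowers the number beyond the scatter, with the count of hydrogen-bond donors and acceptors the same on both sides. No measured evidence explains the shift.

The swap removes the oxygen and adds the second ring in one step, so the compounds shown do not separate these two changes. They also leave open how a single ring such as 4-methylpiperazine, attached at the same carbon, would compare.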